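Trading a methoxy for fluoro on an inactive scaffold

This account rests on a few compounds, and the source may have more. Where it says the series, first, only, none or still open, it means among the compounds named here.

Measured so far:
- compound 1, `COc1ccc(-c2csc(Cn3ccnc3)c2)cc1OC`: 0%
- compound 2, `COc1ccc(-c2csc(Cn3ccnc3)c2)cc1`: 0%

Both compounds were tested in an assay for inhibition of steroid 17-alpha-hydroxylase/17,20 lyase (Homo sapiens), using NADPH, tested at 0.2 uM; a higher number here means a stronger effect of the compound at the concentration tested, a lower number a weaker effect. Compound 2 stands level with compound 1 at the digits printed; the step of no change at the digits printed from compound 1 to compound 2 (within the scatter) stayed within the scatter, so taking away one methoxy group made no visible difference. Compound 3, `Fc1ccc(-c2csc(Cn3ccnc3)c2)cc1`, is the next compound, not yet measured. It differs from compound 2 by fluoro in place of methoxy on an aromatic carbon. Among the measured compounds shown here, the only step that bears on it is the one from compound 1 to compound 2, in which a methoxy group was removed without effect. The methoxy that now gives way to fluoro therefore has no shown weight in this series, and no step beyond the scatter is expected in this assay, in either direction. For compound 3 the expected step is a number 2 percentage points higher from compound 2 to compound 3 (within the scatter), and the estimated value is 2%, between -8% and 14%.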

Compound 3, a percentage reported as inhibition, at one concentration (the size of the read-out at that concentration, not a potency): 0%
Compound 3: middle estimate off by 2 percentage points, on the high side, within the range that was stated.
By their numbers in this assay, from the lowest: compounds 1, 2 and 3 (each within the scatter of the next).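

In this assay, replacing methoxy with fluoro gives no change at the digits printed from compound 2 to compound 3 (within the scatter). Among the compounds shown here, until now, the only change seen was the loss of one methoxy group; this result adds that the remaining methoxy, para to a large group, can also give way to a smaller atom without any visible effect on the read-out. Since all three compounds read the same, this series has not yet shown any group at this position that moves the number, and nothing measured here offers an explanation for that.

Going by these compounds, it remains open whether an amine, a carboxylic acid or a longer chain at this position would produce a measurable read-out. A single-concentration test that reads the same for all three also leaves open whether methoxy and fluoro would differ at a higher concentration.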